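The source may hold more compounds than are shown below. What is called first, only, known or untested is meant among the compounds shown, and "the series" means these compounds.

Of the compounds shown here, three have so far been measured in an in vitro assay on HEK-tsA201 cells for antagonist activity at Neuronal acetylcholine receptor; alpha4/beta2 (Homo sapiens), read by fluorescence and calcium flux; on this read-out higher numbers stand for weaker inhibition and lower numbers for stronger inhibition. Compound 1 `C=CCOc1ccc(C(=O)Nc2cccc(CC)n2)cc1` gives 20500 nM in this assay. Compound 2 `CCCCNc1cccc(NC(=O)c2ccc(OCCC)cc2)n1`, which carries a butylamino group on the shared core, gives 54100 nM in this assay. Compound 3 `CCCCCCNc1cccc(NC(=O)c2ccc(OCCC)cc2)n1` is reported in this assay only as a limit, > 100000 nM, so compound 3 stands at the limit of > 100000 nM in this assay, at which 1 of the 3 values shown sits, and not at a measured number. For the measured compounds named here, the single step between compounds that differ in one place is an at least 1.8-fold higher number from compound 2 to compound 3 (0.26 log units; that floor lies within the scatter), a lengthening of the chain on the ring nitrogen that carries the result from a measured number to a limit.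

Compound 4 `CCCOc1ccc(C(=O)Nc2cccc(N3CCCCC3)n2)cc1` differs from compound 3 by piperidin-1-yl in place of hexylamino on an aromatic carbon. Going by the values given here, the measured step concerns extension of an open chain rather than its closure into a ring, and no measured pair shows a ring at this place, so the data give no direct guide to the direction of the change. Compound 3 itself offers only a floor. The expected step is an at least 1.2-fold lower number from compound 3 to compound 4 (0.09 log units; that floor lies within the scatter). For compound 4 the estimate in this assay is 80000 nM, within a range from 25000 nM to 250000 nM.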

Compound 4, half-maximal inhibitory concentration: > 100000 nM
Compound 4 ended at the assay's limit; the forecaster's own chance of this, stated with the estimate: 45%; middle value at least 1.2-fold (0.09 log units) away from the limit.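

Putting a ring at this place did not bring back a measured number, and compound 4, which has piperidin-1-yl in place of the open chain and no hydrogen-bond donor in that group, is reported only as a limit in this assay: the limit of > 100000 nM in this assay, at which 2 of the 4 values shown sit. Compared with the butylamino group, the ring gives an at least 1.8-fold higher number from compound 2 to compound 4 (0.26 log units; that floor lies within the scatter), so this floor alone does not establish a real loss on going from the open chain to the ring. Both compound 3 and compound 4 are limits, so the step from hexylamino to piperidin-1-yl cannot be read, and the result shows only that neither the longer chain nor this ring gives a measured number.

The compounds shown leave open whether a smaller ring such as pyrrolidin-1-yl, a ring with a second hetero atom such as morpholin-4-yl, or a shorter chain such as ethylamino would give a measured number at this place. They also leave open what compound 3 and compound 4 would read without the limit, and whether the two would differ at all.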